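Replacing 4-Cyanophenyl with 2-Methoxyphenyl: What to Expect

A few compounds are considered here, and "the series" means these few. Any claim that something is new, unique, unknown or untested is made for them only; others in the source may bear on it.

Three compounds have been measured in a functional assay on PC-12 cells (Rattus norvegicus) for cytotoxicity, read by MTT assay, with stated times of 2 h and 24 h, tested at 1 uM; on this read-out higher numbers stand for a stronger effect at the one concentration tested and lower numbers for a weaker effect:
Compound 1, `CC(C)(C)c1ccc(-n2nc(-c3ccc(C(F)(F)F)cc3O)nc2-c2ccccc2O)cc1`, gives 67.3%.
Compound 2, `Oc1cc(C(F)(F)F)ccc1-c1nc(-c2ccccc2O)n(-c2ccc(C(F)(F)F)cc2)n1`, gives 70.7%.
Compound 3, `N#Cc1ccc(-n2nc(-c3ccc(C(F)(F)F)cc3O)nc2-c2ccccc2O)cc1`, gives 66.6%.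

On these numbers compound 3 sits at the bottom of the three, though not apart from the others: a number 0.7 percentage points lower from compound 1 to compound 3 (within the scatter) and a number 4.1 percentage points lower from compound 2 to compound 3 (within the scatter). Compound 4, `COc1ccccc1-n1nc(-c2ccc(C(F)(F)F)cc2O)nc1-c1ccccc1O`, differs from compound 3 in one place: 2-methoxyphenyl in place of 4-cyanophenyl on an aromatic nitrogen. Every measured step also changed only the group carried on the ring attached to that aromatic nitrogen, and none moved the read-out beyond the scatter: a number 3.4 percentage points higher from compound 1 to compound 2 (within the scatter), a number 0.7 percentage points lower from compound 1 to compound 3 (within the scatter), a number 4.1 percentage points lower from compound 2 to compound 3 (within the scatter). The present swap exchanges the whole ring, a larger change than any measured, so the expectation is less certain. Still, with no step beyond the scatter to build on, compound 4 is expected to show no change beyond the scatter, a number 0.4 percentage points higher from compound 3 to compound 4 (within the scatter). Compound 4 is therefore estimated at 67%, between 55% and 78%.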

Compound 4, a percentage reported as activity, at one concentration (the size of the read-out at that concentration, not a potency): 70.7%
Estimate against measurement, compound 4: 3.7 percentage points below; measured number inside the range.
By their numbers in this assay, from the lowest: compounds 3, 1, 2 and 4 (each within the scatter of the next).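

Exchanging the whole ring on the aromatic nitrogen, and not only the group it carries, still gives no step beyond the scatter in this assay: there is a number 4.1 percentage points higher from compound 3 to compound 4 (within the scatter), a number 3.4 percentage points higher from compound 1 to compound 4 (within the scatter) and no change at the digits printed from compound 2 to compound 4 (within the scatter) on this read-out. This read-out therefore does not separate 2-methoxyphenyl from the three phenyl groups substituted at the 4 position. Nothing available gives a reason for this. Still open, as far as these compounds go, is whether a phenyl ring carrying an amine or a carboxylic acid, or a longer chain in place of the ring, would stay within the scatter.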